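Chloro for Fluoro on the Outer Phenyl of Compound 2

A few compounds are considered here, and "the series" means these few. Any claim that something is new, unique, unknown or untested is made for them only; others in the source may bear on it.

Measured compounds:
Compound 1, `N=C(N)c1ccc(-c2ccc(-c3cc(Cl)cc(Cl)c3)s2)cc1`, gives 2050 nM
Compound 2, `N=C(N)c1ccc(-c2ccc(-c3ccc(F)cc3)s2)cc1`, gives 1650 nM
Compound 3, `COc1cc(OC)cc(-c2ccc(-c3ccc(C(=N)N)c(F)c3)s2)c1`, gives 1370 nM

Of the compounds shown here, three have been tested in a functional assay on BT-549 cells (Homo sapiens) for inhibition, read by sulforhodamine B assay, with a stated time of 48 h; on this read-out higher numbers stand for weaker inhibition of growth and lower numbers for stronger inhibition of growth. On these numbers compound 2 stands second highest of the three; its nearest neighbour is compound 3 and its furthest is compound 1, and both gaps lie within the scatter, so the three values cannot be told apart. Compound 4, `N=C(N)c1ccc(-c2ccc(-c3ccc(Cl)cc3)s2)cc1`, has not yet been measured. It differs from compound 2 in a single place: chloro in place of fluoro on an aromatic carbon. Among the compounds with values here, compounds 1 and 3 carry other groups on other rings and form no one-place pair with either compound 2 or compound 4, so they offer no step to lean on. Within the data shown here, nothing among the measured compounds points to a shift in either direction for this exchange, so the step of a 1.1-fold lower number from compound 2 to compound 4 (0.04 log units; within the scatter) is expected to stay within the scatter of this assay . Compound 4 is therefore expected to give 1500 nM, with a range from 700 nM to 3200 nM.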

Compound 4, concentration for 50% growth inhibition: 1730 nM
For compound 4 the middle estimate is 1.2-fold (0.06 log units) below the measured one; low and high end bracket the measured number.
By their numbers in this assay, from the lowest: compounds 3, 2, 4 and 1 (each within the scatter of the next).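

In this assay, within the data shown here, the change from 4-fluorophenyl to 4-chlorophenyl amounts to a 1.0-fold higher number from compound 2 to compound 4 (0.02 log units; within the scatter) and is the first step in this set that isolates a single place. At this position, para to a large group, chloro can therefore stand in place of fluoro with no shift that this read-out can resolve. No independent measurement offers an account of why the two compounds read alike.

On these data alone, whether the position accepts groups other than these two stays open: an amine, a carboxylic acid or a methoxy group in the same place could behave quite differently. This single step also leaves open whether chloro in place of fluoro would read the same with other groups elsewhere on the shared core.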